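Replacing a Substituted Phenyl with Dimethylisoxazole: Compound 4

This account rests on a few compounds, and the source may have more. Where it says the series, first, only, none or still open, it means among the compounds named here.

Measured so far in a functional assay on CHO cells for agonist activity at Free fatty acid receptor 1 (Homo sapiens), read by FLIPR and calcium flux; a higher number here means that more compound is needed for the effect, a lower number that less compound is needed:
compound 1 `O=C(O)CS(=O)(=O)c1ccc(OCc2cccc(-c3ccccc3F)c2)cc1`: 257 nM
compound 2 `O=C(O)CS(=O)(=O)c1ccc(OCc2cccc(-c3ccccc3Cl)c2)cc1`: 28.8 nM
compound 3 `CC(C)c1ccccc1-c1cccc(COc2ccc(S(=O)(=O)CC(=O)O)cc2)c1`: 74.1 nM

Compound 3 stands second highest of the three numbers in this assay. The steps of a 2.6-fold higher number from compound 2 to compound 3 (0.41 log units; beyond the scatter) and a 3.5-fold lower number from compound 1 to compound 3 (0.54 log units; beyond the scatter) place it between the other two.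

Compound 4 `Cc1noc(C)c1-c1cccc(COc2ccc(S(=O)(=O)CC(=O)O)cc2)c1` differs from compound 3 by the change (3,5-dimethyl-1,2-oxazol-4-yl in place of 2-isopropylphenyl on an aromatic carbon). Every measured step swaps a single group on an aromatic carbon, namely an 8.9-fold lower number from compound 1 to compound 2 (0.95 log units; beyond the scatter), a 3.5-fold lower number from compound 1 to compound 3 (0.54 log units; beyond the scatter) and a 2.6-fold higher number from compound 2 to compound 3 (0.41 log units; beyond the scatter), all modest; none exchanges the whole aromatic group, so the bearing on this step is indirect and only a modest shift, in either direction, is expected. Compound 4 is therefore expected near 150 nM, within 40 nM to 600 nM, an expected step of a 2.0-fold higher number from compound 3 to compound 4 (0.31 log units; beyond the scatter).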

Compound 4, half-maximal effective concentration: 269 nM
Estimate against measurement, compound 4: 1.8-fold (0.25 log units) below, and the stated range covers the measured number.
By their numbers in this assay, from the lowest: compound 2; then compound 3; then compounds 1 and 4 (each within the scatter of the next).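

Compound 4 shows that the whole aromatic group at this position can be exchanged, not only a single substituent on it, and in this assay the five-membered ring gives a 3.6-fold higher number from compound 3 to compound 4 (0.56 log units; beyond the scatter) and a 9.3-fold higher number from compound 2 to compound 4 (0.97 log units; beyond the scatter) in the same assay. Set against the 2-fluorophenyl group, the same exchange gives a 1.0-fold higher number from compound 1 to compound 4 (0.02 log units; within the scatter) and so cannot be told apart from it. Nothing given here accounts for these steps.

The compounds shown leave open whether a pyridine ring or an unsubstituted phenyl at this place would come closer to compound 2. They also leave open what each methyl on the 3,5-dimethyl-1,2-oxazol-4-yl group contributes.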